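From a methyl limit to an amino group

The source may report more compounds than this note shows. Statements on the series, on what has been measured and on what is new or still open speak of the compounds shown alone.

Measured in a functional assay on NCI-H460 cells (Homo sapiens) for antiproliferative activity, read by MTT assay, with a stated time of 48 h; on this read-out higher numbers stand for weaker inhibition and lower numbers for stronger inhibition:
Compound 1 `COc1cc(-c2cccc3nc(-c4ccccc4)oc23)cc(OC)c1OC`: 6800 nM
Compound 2 `COc1cc(-c2cccc3nc(-c4cccc(F)c4)oc23)cc(OC)c1OC`: 3300 nM
Compound 3 `COc1cc(-c2cccc3nc(-c4cccc(C)c4)oc23)cc(OC)c1OC`: > 25000 nM, a limit

On these numbers compound 3 stands at the limit of > 25000 nM in this assay, at which 1 of the 3 values shown sits. Compound 4 `COc1cc(-c2cccc3nc(-c4cccc(N)c4)oc23)cc(OC)c1OC` differs from it by amino in place of methyl on an aromatic carbon. Among the compounds with values here, no amino compound has been measured, so only three steps bear on this change. Methyl gave an at least 3.6-fold higher number from compound 1 to compound 3 (0.56 log units; beyond the scatter) and an at least 7.5-fold higher number from compound 2 to compound 3 (0.87 log units; beyond the scatter), while fluoro gave a 2.1-fold lower number from compound 1 to compound 2 (0.31 log units; beyond the scatter). Only methyl raised the number, so leaving it should lower the number in this assay, though the size is uncertain. The expected change is an at least 4.1-fold lower number from compound 3 to compound 4 (0.61 log units; beyond the scatter). For compound 4 the estimate is 6000 nM, with an expected range of 1800 nM to 20000 nM.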

Compound 4, half-maximal inhibitory concentration: 2600 nM
Estimate against measurement, compound 4: 2.3-fold (0.36 log units) above; low and high end bracket the measured number.
By their numbers in this assay, from the lowest: compounds 4 and 2 (each within the scatter of the next); then compound 1. At a limit, above all of these: compound 3.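

Compound 3 stands at a limit and not at a number: the limit of > 25000 nM in this assay, at which 1 of the 4 values shown sits.

In this assay, amino in place of methyl gives an at least 9.6-fold lower number from compound 3 to compound 4 (0.98 log units; beyond the scatter), so the loss seen with methyl at this position does not extend to every group placed there. Amino also gives a 2.6-fold lower number from compound 1 to compound 4 (0.42 log units; beyond the scatter), which makes it the second group after fluoro to beat hydrogen here, while a 1.3-fold lower number from compound 2 to compound 4 (0.10 log units; within the scatter) leaves amino and fluoro level.

The compounds shown leave open whether a hydroxyl or a methoxy at this place would follow amino or methyl. They also leave open whether an amide built on the amino group would keep its value.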